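The source may hold more compounds than are shown below. What is called first, only, known or untested is meant among the compounds shown, and "the series" means these compounds.

Measured compounds in an assay on HeLa cells for displacement of a labelled ligand from 5-hydroxytryptamine receptor 6 (Homo sapiens); a higher number here means a weaker inhibitor, a lower number a stronger inhibitor:
- compound 1, `C/C(=N\NC(=N)N)c1c[nH]c2ccc(NS(=O)(=O)c3ccccc3)cc12`: 1 nM
- compound 2, `COc1ccc(S(=O)(=O)Nc2ccc3[nH]cc(/C(C)=N/NC(=N)N)c3c2)cc1`: 1 nM
- compound 3, `C/C(=N\NC(=N)N)c1cn(S(=O)(=O)c2ccc(N)cc2)c2ccccc12`: <= 8 nM (a limit, not a number)

Among the measured compounds shown here, compound 1 and compound 2 both sit at the low end of the values shown; the single measured step, no change at the digits printed from compound 1 to compound 2 (within the scatter), is within the scatter. For compound 3 only a limit is reported: it sits at the limit of <= 8 nM in this assay, at which 1 of the 3 values shown sits, so its true value is not fixed on the numbers shown, only bounded.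

Compound 4, `C/C(=N\NC(=N)N)c1cn(S(=O)(=O)c2c(Cl)nc3sccn23)c2ccccc12`, is not yet measured. It differs from compound 3 by a group of 9 heavy atoms (5 carbon, 2 nitrogen, 1 sulfur, 1 chlorine; 2 five-membered aromatic rings with 2 hetero atoms each) in place of a group of 7 heavy atoms (6 carbon, 1 nitrogen; one six-membered aromatic ring of carbon only), on a sulfonyl sulfur. For the measured compounds named here, no measured step involves this sulfonyl substituent; the one step available, from compound 1 to compound 2, concerns a methoxy on a different part of the series and gave no change, so it does not bear on this replacement. Going by the values given here, with no comparable step, the expectation rests on compound 3 standing at a limit and on the size of the change. The step of an at least 1.5-fold higher number from compound 3 to compound 4 (0.17 log units; that floor lies within the scatter) is expected to be modest, direction uncertain, with a wide range. Compound 4 is estimated at 12 nM, between 2 nM and 80 nM.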

Compound 4, inhibition constant: <= 8 nM
Compound 4: only a limit was reported; the forecaster's own chance of this, stated with the estimate: 30%; middle value at least 1.5-fold (0.17 log units) away from the limit.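

In this assay, compound 3 and compound 4 each carry only a limit, not a number, so no step between them can be read: the limit of <= 8 nM in this assay, at which 2 of the 4 values shown sit.

The compounds shown leave open whether replacing 4-aminophenyl on the sulfonyl sulfur changes the true value in this assay, and in which direction.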